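A few compounds are considered here, and "the series" means these few. Any claim that something is new, unique, unknown or untested is made for them only; others in the source may bear on it.

Working notes on the series. Within the data shown here, in a functional assay on MCF7 cells (Homo sapiens) for cytotoxicity, read by MTT assay, with a stated time of 72 h (on this read-out higher numbers stand for weaker inhibition and lower numbers for stronger inhibition), compound 1 (`O=C(NCc1ccc(F)cc1)c1nc(Br)c2cccnc2c1N1CCNCC1`) reads 7000 nM and is the only number so far. Compound 2 (`CNc1c(C(=O)NCc2ccc(F)cc2)nc(Br)c2cccnc12`) stands at "not determined" (no result reported) on the same read-out, so it has no place on the scale and offers no baseline. Compound 3 (`NCCCCCCNc1c(C(=O)NCc2ccc(F)cc2)nc(Br)c2cccnc12`) has not yet been measured. The structural change is 5-aminopentyl in place of hydrogen on a saturated chain carbon bound to a nitrogen on an aromatic ring with 5-aminopentyl in place of hydrogen on a saturated chain carbon bound to a nitrogen on an aromatic ring. Among the measured compounds shown here, no measured step exists to size this change. Only a modest move toward stronger inhibition in this assay is expected, with compound 1 at 7000 nM as the sole reference and wide uncertainty. Compound 3 is estimated at 3000 nM with an expected range from 700 nM to 12000 nM in this assay once tested.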

Compound 3, half-maximal inhibitory concentration: 2000 nM
Compound 3: the middle estimate sits 1.5-fold (0.18 log units) above what was measured, within the range that was stated.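

In this assay, among these compounds, (6-aminohexyl)amino in place of piperazin-1-yl on an aromatic carbon gives a 3.5-fold lower number from compound 1 to compound 3 (0.54 log units; beyond the scatter), the first sized change at this position, and it shows that the piperazin-1-yl ring is not needed for a measurable read-out there. The step from compound 2 to compound 3 cannot be read, as compound 2 has no result, so the 5-aminopentyl extension has no size of its own. No measurement shown bears on why the number moves.

On these data alone, whether the chain length matters stays open, since neither a shorter nor a longer chain appears beside the 6-aminohexyl chain. Also open, as far as these compounds go, is what a hydroxyl or a carboxylic acid would do in place of the chain's end amine.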